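Removing a phenyl from the anilino nitrogen of compound 2

A few compounds are considered here, and "the series" means these few. Any claim that something is new, unique, unknown or untested is made for them only; others in the source may bear on it.

Measured compounds:
- compound 1, `CCOC(=O)c1c(-c2ccc(C)cc2)cc(-c2ccccc2)nc1N1CCN(c2nc(-c3ccccc3)cc(-c3ccc(C)cc3)c2C(=O)OCC)CC1`: 229000 nM
- compound 2, `CCOC(=O)c1c(-c2ccc(F)cc2)cc(-c2ccccc2)nc1Nc1ccccc1`: 367000 nM

Both compounds were tested in a functional assay on thoracic aorta (strain Wistar) with Aorta (Rattus norvegicus) as the target, with a stated time of 2 h; a higher number here means a weaker inhibitor, a lower number a stronger inhibitor. Compound 1 gives 229000 nM, and compound 2 gives 367000 nM. Compound 2 has the higher of the two numbers, but its nearest neighbour, compound 1, lies within the usual scatter of this assay, so the two numbers cannot be told apart with confidence.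

The next compound, compound 3, `CCOC(=O)c1c(-c2ccc(F)cc2)cc(-c2ccccc2)nc1N`, is not yet measured. It differs from compound 2 in one place: hydrogen in place of phenyl on a nitrogen on an aromatic ring, which reads as anilino to amino. Going by the values given here, no measured pair in this set shows what such a change does, so the expectation rests on compound 2 alone.

With no guide to the size of this step, the expected change from compound 2 to compound 3 in this assay is a 1.1-fold higher number from compound 2 to compound 3 (0.04 log units; within the scatter), which is not expected to go beyond the scatter in either direction. Compound 3 is therefore estimated to give 400000 nM in this assay, with a range from 150000 nM to 1100000 nM.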

Compound 3, half-maximal inhibitory concentration: 335000 nM
Estimate against measurement, compound 3: 1.2-fold (0.08 log units) above, within the range that was stated.
By their numbers in this assay, from the lowest: compounds 1, 3 and 2 (each within the scatter of the next).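

In this assay, hydrogen in place of phenyl on a nitrogen on an aromatic ring gives a 1.1-fold lower number from compound 2 to compound 3 (0.04 log units; within the scatter), so the anilino and amino forms cannot be told apart at this position. Going by these compounds alone, this is the first step that can be read at this nitrogen, since compound 1 and compound 2 differ in more than one place and their pair says nothing about any single group. Here a whole phenyl ring can be exchanged for a lone hydrogen with the number staying within the scatter, but nothing measured on these compounds offers an explanation for that.

Still open, from the compounds shown here alone, is whether any other group on this nitrogen would give a number beyond the scatter, such as a methyl, a longer alkyl chain, or a chain ending in an amine or a carboxylic acid. Within the data shown here, with only one step in one assay, it is also open whether the anilino to amino change would read the same way on a different core.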